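Adding an aromatic ester to the hydroxy group of compound 1

This account rests on a few compounds, and the source may have more. Where it says the series, first, only, none or still open, it means among the compounds named here.

Within the data shown here, in a functional assay on CaEs17 cells (Homo sapiens) for cytotoxicity, read by MTT assay, with a stated time of 72 h (a higher number here means a weaker inhibitor, a lower number a stronger inhibitor), compound 1 `C=C1C(=O)[C@@]23C(=O)OC[C@]4(C(=O)CCC(C)(C)[C@H]4C=O)[C@@H]2CC[C@@H]1[C@H]3O` gives 5850 nM as the higher of the two numbers measured so far. Among the measured compounds shown here, the only other measured compound is compound 2 `C=C1C(=O)[C@@]23C(=O)OC[C@]4(C(=O)CCC(C)(C)[C@H]4C=O)[C@@H]2CC[C@@H]1[C@H]3OC(=O)c1ccccc1` with 1710 nM as its result. Placing benzoyl in place of hydrogen on an oxygen on a saturated carbon gave a 3.4-fold lower number from compound 1 to compound 2 (0.53 log units; beyond the scatter) as a modest change.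

Compound 3 `C=C1C(=O)[C@@]23C(=O)OC[C@]4(C(=O)CCC(C)(C)[C@H]4C=O)[C@@H]2CC[C@@H]1[C@H]3OC(=O)c1ccc(C)cc1` is altered at an oxygen on a saturated carbon too, and (4-methylphenyl)carbonyl in place of hydrogen on an oxygen on a saturated carbon describes that change. In words, (4-methylphenyl)carbonyl stands in place of hydrogen. For the measured compounds named here, this entering group resembles the benzoyl of compound 2, so the single measured step is the closest guide. Going by the values given here, it remains thin evidence, since no compound carrying (4-methylphenyl)carbonyl has been measured yet.

A lower number of similar size is therefore expected, and the estimated step is a 3.7-fold lower number from compound 1 to compound 3 (0.56 log units; beyond the scatter) in this assay for now. For compound 3 the estimate is 1600 nM as the central value, with an expected range from 700 nM to 3800 nM around it.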

Compound 3, half-maximal inhibitory concentration: 1050 nM
Compound 3: middle estimate off by 1.5-fold (0.18 log units), on the high side; the measured number falls inside the stated range.
By their numbers in this assay, from the lowest: compounds 3 and 2 (each within the scatter of the next); then compound 1.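

The second aromatic ester shows that the lower number seen with benzoyl is not unique to that one group: in this assay the (4-methylphenyl)carbonyl ester gives a 5.6-fold lower number from compound 1 to compound 3 (0.75 log units; beyond the scatter) and so also stands clearly apart from the free hydroxy group. The extra methyl on the aromatic ring adds no readable change, as replacing hydrogen on an aromatic carbon with methyl gives a 1.6-fold lower number from compound 2 to compound 3 (0.21 log units; within the scatter) and the two esters therefore cannot be separated in this assay. At this oxygen, then, the two aromatic esters agree in direction and differ clearly from the hydroxy compound, but no measurement here explains why the number shifts.

The compounds shown leave open whether the six-membered aromatic ring is needed at all, or whether a simple acetyl ester or an ester with a longer chain would give a similar number. They also leave open how much the aromatic ring tolerates, since a single methyl says little about what an amine or a carboxylic acid in its place would do.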